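The source may hold more compounds than are shown below. What is called first, only, known or untested is meant among the compounds shown, and "the series" means these compounds.

Series notes. In a functional assay on BXPC-3 cells (Homo sapiens) for inhibition, read by MTT assay, with a stated time of 7 days (a higher number here means a weaker inhibitor, a lower number a stronger inhibitor), compound 1 `CCN(CC)S(=O)(=O)c1ccc(S(=O)(=O)N2CCC[C@@H](C(=O)N(C)C(C)C)C2)cc1` gives 7700 nM. Two further members have been run: compound 2 `CCOC(=O)[C@@H]1CCCN(S(=O)(=O)c2ccc(S(=O)(=O)N(CC)CC)c(F)c2)C1` gives 1600 nM, and compound 3 `CCOC(=O)[C@@H]1C[C@@H](O)CN(S(=O)(=O)c2ccc(S(=O)(=O)N(CC)CC)cc2)C1` gives 10800 nM. Compound 1 thus sits second highest of the three numbers. Its value and that of compound 3 lie within the usual scatter of each other, so no order is read between those two, whereas compound 2 stands below compound 1 by a margin beyond the scatter. Among the compounds with values here, compounds 2 and 3 each differ from compound 1 in more than one place, so no single step is drawn from either of them.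

Compound 4 `CCN(CC)S(=O)(=O)c1ccc(S(=O)(=O)N2CCC[C@@H](C(=O)NC3CN(C(=O)OC(C)(C)C)C3)C2)cc1` has not yet been measured in this assay. It differs from compound 1 in one place: (1-(tert-butoxycarbonyl)azetidin-3-yl)amino in place of isopropyl(methyl)amino on a carbonyl carbon. Within the data shown here, no measured pair shows a change of this kind at the carbonyl carbon, so there is nothing to set its size or direction against; the working expectation is a step no larger than the scatter, with the direction left open and the range kept wide. Compound 4 is accordingly expected to give about 6000 nM in this assay, with a range from 1500 nM to 24000 nM. The estimated step from compound 1 to compound 4 is a 1.3-fold lower number from compound 1 to compound 4 (0.11 log units; within the scatter).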

Compound 4, half-maximal inhibitory concentration: 1800 nM
Beside the measured number, compound 4's estimate is 3.3-fold (0.52 log units) above it; low and high end bracket the measured number.
By their numbers in this assay, from the lowest: compounds 2 and 4 (each within the scatter of the next); then compounds 1 and 3 (each within the scatter of the next).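

In this assay, within the data shown here, the carbonyl carbon on the saturated ring carbon proves to be a position where the group can change the read-out: (1-(tert-butoxycarbonyl)azetidin-3-yl)amino in place of isopropyl(methyl)amino gives a 4.3-fold lower number from compound 1 to compound 4 (0.63 log units; beyond the scatter), the only single-place step so far. The position therefore accepts a far larger group without any loss in this assay, with 12 heavy atoms entering against 5 leaving, along with a four-membered non-aromatic ring, a hydrogen-bond donor and hydrogen-bond acceptors. These features all change together in one step, and no supporting data are available to account for the result.

Which part of the entering group goes with the lower number remains open, since the tert-butoxycarbonyl group, the azetidine ring and the amide hydrogen are not separated by any compound shown. The unprotected azetidin-3-ylamino group, the plain cyclobutylamino group and an acetyl group in place of tert-butoxycarbonyl on the azetidine nitrogen would each address part of that question.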